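A few compounds are considered here, and "the series" means these few. Any claim that something is new, unique, unknown or untested is made for them only; others in the source may bear on it.

Compound 1 (`Cc1cc([N+](=O)[O-])ccc1Nc1cccc(Cn2ccnc2)c1`) gives > 100000 nM
Compound 2 (`Clc1ccc(Oc2cccc(Cn3ccnc3)c2)cc1`) gives > 100000 nM

Both readings come from an ADME assay on NIH3T3 cells (Mus musculus) for cytotoxicity (on this read-out lower numbers stand for an effect already at smaller amounts and higher numbers for an effect only at larger amounts of compound), and neither is a number. Going by the values given here, the position so far is the limit of > 100000 nM in this assay, at which 2 of the 2 values shown sit, and compound 2 shares it. For compound 2, the entry > 100000 nM is a limit of the assay.

The next compound is compound 3 (`c1ccc(Oc2cccc(Cn3ccnc3)c2)cc1`), with hydrogen in place of chloro on an aromatic carbon, para to a large group (hydrogen in place of chloro on an aromatic carbon). Among the compounds with values here, no measured pair shows what such a change does in this assay. The expectation rests on compound 2, with its limit of > 100000 nM as the only anchor. The estimated a number no higher from compound 2 to compound 3 (the limit leaves the size open) is expected to stay within the scatter, and another limit reading is likely. For compound 3 the expected value is 100000 nM with an estimated range from 50000 nM to 200000 nM as the working figure.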

Compound 3, half-maximal effective concentration: > 100000 nM
Compound 3: a limit, no number; the forecaster's own chance of this, stated with the estimate: 85%; the middle value lies on the limit itself.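

Compound 2 and compound 3 both give limits, not numbers, in this assay, and the step between them cannot be read. The compounds shown leave open what hydrogen in place of chloro on an aromatic carbon does here, and at what concentration any of them would register an effect.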